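This account rests on a few compounds, and the source may have more. Where it says the series, first, only, none or still open, it means among the compounds named here.

Series notes. Compound 1 `O=C(Nc1ccccc1)c1csc(Cc2c(Cl)cccc2Cl)n1` is the plain anilide of the shared core. In an assay on CHO cells, read by calcium flux (on this read-out higher numbers stand for weaker inhibition and lower numbers for stronger inhibition), compound 1 gives > 4000 nM, which is a limit of the assay and not a number, as recorded in the limit of > 4000 nM in this assay, at which 1 of the 2 values shown sits. Compound 2 `O=C(Nc1ccc(C(F)(F)F)cc1)c1csc(Cc2c(Cl)cccc2Cl)n1` carries trifluoromethyl in place of hydrogen on an aromatic carbon; in this assay compound 2 gives 140 nM. Going by the values given here, the single measured step, an at least 28-fold lower number from compound 1 to compound 2 (1.45 log units; beyond the scatter), shows that compound 1 stands at the weak end of what has been seen. Compound 3 `O=C(Nc1cccc(Br)c1)c1csc(Cc2c(Cl)cccc2Cl)n1` differs from compound 1 as follows: bromo in place of hydrogen on an aromatic carbon. Among the compounds with values here, only the step from compound 1 to compound 2 bears on this, and it concerned a different group, so its size is taken as a ceiling rather than a guide; a downward step in this assay is expected, smaller than the one measured. For compound 3 the estimate is 900 nM, with a range of 250 nM to 4000 nM. That amounts to an expected step of an at least 4.4-fold lower number from compound 1 to compound 3 (0.64 log units; beyond the scatter) for compound 3.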

Compound 3, half-maximal inhibitory concentration: > 4000 nM
Compound 3 gave a limit, no number; the forecaster's own chance of this, stated with the estimate: 25%; at least 4.4-fold (0.64 log units) between middle value and limit.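

No new step can be read between compound 1 and compound 3, because both sit at a limit of the assay and not at a number: the limit of > 4000 nM in this assay, at which 2 of the 3 values shown sit. The compounds shown leave open whether bromo in place of hydrogen changes the result in this assay at all.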